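Aryl Substituent Swap: Forecasting a Trifluoromethyl Variant

The source may hold more compounds than are shown below. What is called first, only, known or untested is meant among the compounds shown, and "the series" means these compounds.

Compound 1 `CC#CC(CC(=O)O)c1ccc(OCc2ccn3cc(-c4ccccc4)nc3c2)cc1` gives 1260 nM in an assay on isolated protein for agonist activity at Free fatty acid receptor 1 (Homo sapiens); on this read-out lower numbers stand for an effect already at smaller amounts and higher numbers for an effect only at larger amounts of compound.
Compound 2 `CC#CC(CC(=O)O)c1ccc(OCc2ccn3cc(-c4ccc(C(C)C)cc4)nc3c2)cc1` gives 615 nM in this assay.
Compound 3 `CC#CC(CC(=O)O)c1ccc(OCc2ccn3cc(-c4cccc(C)c4)nc3c2)cc1` gives 1510 nM in this assay.

Among these three numbers, compound 3 has the highest. Its nearest neighbour is compound 1: the gap a 1.2-fold higher number from compound 1 to compound 3 (0.08 log units; within the scatter) lies within the scatter, so the two cannot be ranked. Compound 2 sits furthest away, as the step of a 2.5-fold higher number from compound 2 to compound 3 (0.39 log units; beyond the scatter) shows.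

Compound 4 `CC#CC(CC(=O)O)c1ccc(OCc2ccn3cc(-c4ccc(C(F)(F)F)cc4)nc3c2)cc1` has not yet been measured. It differs from compound 3 in one place: 4-(trifluoromethyl)phenyl in place of 3-methylphenyl on an aromatic carbon. Among the compounds with values here, two measured steps bear on this change. Putting an isopropyl group onto the phenyl ring of compound 1 gave a 2.0-fold lower number from compound 1 to compound 2 (0.31 log units; beyond the scatter), whereas a methyl group gave only a 1.2-fold higher number from compound 1 to compound 3 (0.08 log units; within the scatter). The 4-isopropylphenyl compound thus came out ahead of the 3-methylphenyl one. Compound 4 carries a 4-(trifluoromethyl)phenyl group, whose name parallels the 4-isopropylphenyl group of compound 2. On that basis a modest step to a lower number is expected for compound 4, a 2.2-fold lower number from compound 3 to compound 4 (0.33 log units; beyond the scatter). Whether a trifluoromethyl group will behave like an isopropyl group is not known from these three compounds, so the range is kept wide. For compound 4 the estimate in this assay is 700 nM, with a range from 350 nM to 1500 nM.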

Compound 4, half-maximal effective concentration: 674 nM
The estimate for compound 4 lay 1.0-fold (0.02 log units) above the measured number, within the range that was stated.
By their numbers in this assay, from the lowest: compounds 2, 4, 1 and 3 (each within the scatter of the next, the first and the last beyond it).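

Trifluoromethyl and isopropyl, the two groups now seen at the 4-position of this phenyl ring, cannot be told apart in this assay, as a 1.1-fold higher number from compound 2 to compound 4 (0.04 log units; within the scatter) shows. Yet trifluoromethyl also cannot be separated from the plain phenyl ring, with a 1.9-fold lower number from compound 1 to compound 4 (0.27 log units; within the scatter), so compound 4 is level within the scatter with both compound 1 and compound 2, even though those two differ beyond the scatter, and this result alone does not establish a gain from adding trifluoromethyl. Only against the 3-methylphenyl compound does the change clearly register, with a 2.2-fold lower number from compound 3 to compound 4 (0.35 log units; beyond the scatter), and nothing here gives a measured reason for any of these differences.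

That last step changes both the group and where it sits on the phenyl ring, so the compounds shown leave open which of the two matters; a 4-methylphenyl or a 3-(trifluoromethyl)phenyl group would pull them apart. Also open, from the compounds shown here alone, is how this position responds to a group of a different kind, such as an amine or a carboxylic acid on the phenyl ring.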